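Piperidine-carboxamide antagonists: a dimethylphenyl for a chlorophenyl

The compounds below may be only part of what the source reports. "The series", "measured", "known", "first", "only" and "open" are said of these compounds alone.

Two measured compounds anchor this account. Compound 1, `O=C1COc2ccc(NC(=O)C3CCN(c4cccc(Cl)c4)CC3)cc2N1`, gives 190 nM in a functional assay for antagonist activity at transient receptor potential cation channel subfamily V member 1 (Homo sapiens), read by FLIPR and calcium flux; a higher number here means a weaker inhibitor, a lower number a stronger inhibitor. Compound 2, `O=C(Nc1cccc2[nH]ccc12)C1CCN(c2cccc(C(F)(F)F)c2)CC1`, gives 230 nM in this assay. Compound 1 carries the lower of the two numbers, but the gap to compound 2 lies within the scatter of repeated measurements, so the two compounds are not distinguished by these data.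

The unmeasured compound 3, `Cc1cccc(N2CCC(C(=O)Nc3ccc4c(c3)NC(=O)CO4)CC2)c1C`, is reached from compound 1 by a single change: 2,3-dimethylphenyl in place of 3-chlorophenyl on an amine nitrogen in a ring. Among the measured compounds shown here, no step between measured compounds tells how this kind of exchange on an amine nitrogen in a ring plays out here, so any expectation rests on the two numbers alone and on the size of the alteration, which keeps the ring and its lack of donors and acceptors.

The step from compound 1 to compound 3 is expected to be small, a 1.4-fold higher number from compound 1 to compound 3 (0.14 log units; within the scatter), with a slight drift toward a higher number but none that would clearly exceed the scatter. Compound 3 is therefore estimated to give 260 nM in this assay, within a range from 80 nM to 850 nM.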

Compound 3, half-maximal inhibitory concentration: 60 nM
Compound 3: the middle estimate sits 4.3-fold (0.64 log units) above what was measured; measured number outside the range, below it.
By their numbers in this assay, from the lowest: compound 3; then compounds 1 and 2 (each within the scatter of the next).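

Among the compounds shown here, the exchange of 3-chlorophenyl for 2,3-dimethylphenyl on the amine nitrogen of the six-membered ring gives a 3.2-fold lower number from compound 1 to compound 3 (0.50 log units; beyond the scatter) in this assay and provides the only step here between measured compounds that differ in one place. This shows that the number in this assay responds to the group at this position, even though the leaving and entering groups are each one six-membered aromatic ring of carbon only, with no hydrogen-bond donors or acceptors and no net charge. No measurement shown here explains the lower number, so the step stands as an observation about this one pair on this one core.

The compounds shown leave open whether a single methyl group, as in 3-methylphenyl or 2-methylphenyl, would account for the step or whether both methyl groups are needed, and how a 2,3-dichlorophenyl group would compare on the same core. They also leave open whether the 2,3-dimethylphenyl group would give a step of similar size on the core of compound 2, which so far carries a 3-trifluoromethylphenyl group.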